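The source may report more compounds than this note shows. Statements on the series, on what has been measured and on what is new or still open speak of the compounds shown alone.

The series shares the core of compound 1 `CCC1(Cc2ccccc2)OS(=O)(=O)C=C1OCC(=O)OC`. In an ADME assay on HEL cells (Homo sapiens) for cytotoxicity, with a stated time of 3 days (a higher number here means that more compound is tolerated, a lower number that less compound is tolerated), compound 1 gives > 400000 nM, which is a limit of the assay rather than a number. Compound 2 `CCCC1(Cc2ccccc2)OS(=O)(=O)C=C1OCc1ccccc1` is the second member. In this assay compound 2 gives >= 400000 nM, again a limit of the assay and not a number. Compound 1 therefore stands at the top of what this assay can report, as shown by the limit of > 400000 nM in this assay, at which 1 of the 2 values shown sits. The other value sits in the same place, as shown by the limit of >= 400000 nM in this assay, at which 1 of the 2 values shown sits. Going by the values given here, no step between measured compounds is recorded, so the two values show only that both reach a limit.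

Compound 3 `CCC1(Cc2ccccc2)OS(=O)(=O)C=C1OC(=O)c1ccccc1` has yet to be measured in this assay. It differs from compound 1 by benzoyl in place of (methoxycarbonyl)methyl on an oxygen on an unsaturated carbon. With both measured values at a limit there is no basis for expecting a shift beyond the scatter in either direction, so the expected step is none beyond the scatter. The estimate for compound 3 in this assay is 400000 nM, within 200000 nM to 800000 nM. The step this estimate means, a number no higher from compound 1 to compound 3 (the limit leaves the size open), is expected to be negligible, with a strong chance that only a limit is reported again.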

Compound 3, minimum cytotoxic concentration: > 400000 nM
Compound 3 was reported as a limit (the forecaster's own chance of this, stated with the estimate: 85%); the middle value sits exactly at the limit.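

In this assay compound 1 and compound 3 are both reported only as limits, so no step can be read for benzoyl in place of (methoxycarbonyl)methyl on an oxygen on an unsaturated carbon. The compounds shown leave open where the minimum cytotoxic concentration of compound 1, compound 2 or compound 3 actually lies, and what change would bring it within reportable range.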